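Swapping chloro for bromo in a pair of related enones

This account rests on a few compounds, and the source may have more. Where it says the series, first, only, none or still open, it means among the compounds named here.

Of the compounds shown here, three have been measured in a functional assay on DU-145 cells (Homo sapiens) for inhibition, read by trypan blue exclusion, with a stated time of 96 h; on this read-out lower numbers stand for stronger inhibition of growth and higher numbers for weaker inhibition of growth. Compound 1 `COc1ccc(/C=C(\C(=O)c2ccc(Br)cc2)S(=O)(=O)c2ccc(Br)cc2)cc1` gives 25000 nM, compound 2 `COc1ccc(/C=C(\C(=O)c2ccc(Cl)cc2)S(=O)(=O)c2ccc(Br)cc2)cc1` gives 10000 nM, and compound 3 `O=C(/C(=C\c1ccc(F)cc1F)S(=O)(=O)c1ccc(Cl)cc1)c1ccc(Br)cc1` gives 25000 nM. Compound 1 and compound 2 differ only in one place (bromo in place of chloro on an aromatic carbon), and that step made the number rise a 2.5-fold higher number from compound 2 to compound 1 (0.40 log units; beyond the scatter), a modest shift toward weaker inhibition of growth. Compound 3 stands level with compound 1, while its number lies beyond the scatter from that of compound 2. The difference between the cores of compound 3 and compound 2 is not broken down here.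

Compound 4 `O=C(/C(=C\c1ccc(F)cc1F)S(=O)(=O)c1ccc(Br)cc1)c1ccc(Br)cc1` carries the same change relative to compound 3 (bromo in place of chloro on an aromatic carbon), at a place described in the same words. Because the step of a 2.5-fold higher number from compound 2 to compound 1 (0.40 log units; beyond the scatter) weakened inhibition of growth, compound 4 is expected to follow in the same direction, giving an estimated 1.6-fold higher number from compound 3 to compound 4 (0.20 log units; within the scatter). Since compound 3 already sits at the weaker end, the assay may well report only a limit. The estimate for compound 4 in this assay is 40000 nM, expected to fall between 15000 nM and 100000 nM.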

Compound 4, concentration for 50% growth inhibition: 7500 nM
Compound 4: the middle estimate sits 5.3-fold (0.73 log units) above what was measured; measured number below the stated range.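

In this assay, bromo in place of chloro gives a 3.3-fold lower number from compound 3 to compound 4 (0.52 log units; beyond the scatter), the opposite direction to the same swap on the core of compound 1, so the step did not carry over from one core to the other: the same change on two cores in this assay, a 2.5-fold higher number (0.40 log units; beyond the scatter) from compound 2 to compound 1 and a 3.3-fold lower number (0.52 log units; beyond the scatter) from compound 3 to compound 4, 8.3-fold (0.92 log units) apart, beyond the scatter of two such steps

A second step, 2,4-difluorophenyl in place of 4-methoxyphenyl, gives a 3.3-fold lower number from compound 1 to compound 4 (0.52 log units; beyond the scatter), so the outcome of a halogen swap cannot be read apart from the rest of the molecule in these compounds. This shows that the direction of the swap cannot be assumed when moving to a new core in this series, but it does not show why the direction reverses, and the swap does not sit on the same ring in the two pairs.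

The compounds shown leave open how a methyl group, a nitrile or an amine would behave on that aromatic carbon. They also leave open which direction the chloro-to-bromo swap would take on each ring of a single core.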